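Methoxy to chloro on the aryl group at an aromatic nitrogen

The compounds below may be only part of what the source reports. "The series", "measured", "known", "first", "only" and "open" are said of these compounds alone.

Measured so far in a functional assay on NCI-H460 cells (Homo sapiens) for inhibition, read by MTT assay, with a stated time of 72 h; a higher number here means a weaker inhibitor, a lower number a stronger inhibitor:
compound 1 `COc1cc2c(Oc3ccc(NC(=O)c4nn(-c5ccccc5C(F)(F)F)c(=O)cc4C)cc3F)ccnc2cc1OCCCN1CCC(C)CC1` gives 200 nM
compound 2 `COc1ccc(-n2nc(C(=O)Nc3ccc(Oc4ccnc5cc(OCCCN6CCC(C)CC6)c(OC)cc45)c(F)c3)c(C)cc2=O)cc1` gives 4650 nM

Going by the values given here, compound 2 holds the highest of the two numbers in this assay, and its only neighbour is compound 1. Among the compounds with values here, the one measured step, a 23-fold higher number from compound 1 to compound 2 (1.37 log units; beyond the scatter), came from putting 4-methoxyphenyl in place of 2-(trifluoromethyl)phenyl on an aromatic nitrogen, so the group on that nitrogen is clearly where the numbers move.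

Compound 3 `COc1cc2c(Oc3ccc(NC(=O)c4nn(-c5ccc(Cl)cc5)c(=O)cc4C)cc3F)ccnc2cc1OCCCN1CCC(C)CC1` is the next point in that same region: chloro in place of methoxy on an aromatic carbon. Within the data shown here, no measured pair compares chloro with methoxy directly, so the step from compound 1 to compound 2 bears on it only in showing how strongly this assay responds to what sits on the aryl group at that nitrogen. Because compound 2 sits so far above compound 1 at 200 nM, a move away from the methoxy variant is expected to bring the number down rather than up, though by an uncertain amount; the step is estimated as a 3.9-fold lower number from compound 2 to compound 3 (0.59 log units; beyond the scatter). Compound 3 is therefore expected to give about 1200 nM, within a range from 300 nM to 4500 nM.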

Compound 3, half-maximal inhibitory concentration: 370 nM
Compound 3: the middle estimate sits 3.2-fold (0.51 log units) above what was measured; the range from low to high includes it.
By their numbers in this assay, from the lowest: compounds 1 and 3 (each within the scatter of the next); then compound 2.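

In this assay, the change from 4-methoxyphenyl to 4-chlorophenyl gives a 13-fold lower number from compound 2 to compound 3 (1.10 log units; beyond the scatter), so a single substituent on the aryl group at the aromatic nitrogen, para to a large group, is enough to move the number by a large step. The earlier step had replaced 2-(trifluoromethyl)phenyl with 4-methoxyphenyl, changing both the substituent and where it sits on the ring, so it could not separate the two; compound 3 keeps the substituent in the same place as compound 2 and still avoids most of that rise, tying the high number of compound 2 to methoxy rather than to that placement alone. The two differently substituted aryl groups are also not separated in this assay, with a 1.9-fold higher number from compound 1 to compound 3 (0.27 log units; within the scatter), which leaves compound 2 the weakest of the three.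

Nothing shown here explains why methoxy and chloro differ so widely at this place. On these data alone, it remains open how the same ring would read with a methyl, a fluoro or an amine in that place, or with no substituent at all, and so whether methoxy stands alone or marks a wider trend.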